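Adding a Fluoro Group to an Annexin A2/S100-A10 Compound

The source may report more compounds than this note shows. Statements on the series, on what has been measured and on what is new or still open speak of the compounds shown alone.

Compound 1 `Cc1ccc(C(=O)C2=C(O)C(=O)N(CC(C)O)C2c2cc(Cl)cc(Cl)c2)cc1`: 119%
Compound 2 `CCOc1ccccc1C(=O)C1=C(O)C(=O)N(CCCOC)C1c1ccc(C(F)(F)F)cc1`: 117%

Both compounds were tested in an assay on isolated protein for inhibition of annexin A2/S100-A10 (Homo sapiens), with a stated time of 5 min, tested at 50 uM; on this read-out higher numbers stand for more inhibition at the one concentration tested (going by the name of the read-out) and lower numbers for less inhibition. Compound 1 gives 119%, and compound 2 gives 117%; the two values lie within the usual scatter of each other, so compound 2 stands level with compound 1. Compound 3 `CCOc1ccccc1C(=O)C1=C(O)C(=O)N(CCCOC)C1c1ccc(C(F)(F)F)c(F)c1` differs from compound 2 by fluoro in place of hydrogen on an aromatic carbon. Going by the values given here, no measured step of this kind is available. As both measured numbers in this assay lie level with each other, compound 3 is expected to move little in this assay, by a step of a number 2 percentage points lower from compound 2 to compound 3 (within the scatter), none beyond the scatter. Compound 3 is therefore estimated at 115%, within a range of 95% to 125%.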

Compound 3, a percentage reported as inhibition, at one concentration (the size of the read-out at that concentration, not a potency): 127%
Compound 3: the middle estimate sits 12 percentage points below what was measured; the whole stated range lies below it.
By their numbers in this assay, from the lowest: compounds 2, 1 and 3 (each within the scatter of the next).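

Going by these compounds alone, the first one-place change, with fluoro in place of hydrogen on an aromatic carbon ortho to the trifluoromethyl group, gives in this assay a number 10 percentage points higher from compound 2 to compound 3 (within the scatter). This position therefore accepts a fluoro group with no loss of inhibition beyond the scatter at the one concentration tested. Nothing available bears on the reason for this result. As far as these compounds go, what a chloro or methoxy group at this same position would do stays open. From the compounds shown here alone, with a single concentration, any difference in potency between the compounds also remains open.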